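Chloro for Hydrogen on the Aniline Ring: Permeability Account

A few compounds are considered here, and "the series" means these few. Any claim that something is new, unique, unknown or untested is made for them only; others in the source may bear on it.

Measured compounds:
- Compound 1, `O=C(Nc1ccc(F)cc1Cl)c1cc(Cl)ccc1O`: 50.5 10^-6 cm/s
- Compound 2, `O=C(Nc1c(Cl)cc(F)cc1Cl)c1cc(Cl)ccc1O`: 25 10^-6 cm/s
- Compound 3, `O=C(Nc1ccc(C(F)(F)F)cc1)c1cc(Br)ccc1O`: "not determined" (no result reported)

In an ADME assay for permeability, using PAMPA (on this read-out lower numbers stand for lower permeability and higher numbers for higher permeability), compound 1 gives 50.5 10^-6 cm/s. Compound 2 is made from it by one change, (chloro in place of hydrogen on an aromatic carbon), and in this assay compound 2 gives 25 10^-6 cm/s, which amounts to a 2.0-fold lower number from compound 1 to compound 2 (0.31 log units; beyond the scatter).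

Compound 3, `O=C(Nc1ccc(C(F)(F)F)cc1)c1cc(Br)ccc1O`, carries a different core; the difference between the two cores is not broken down here. For compound 3 no number in this assay was reported.

Compound 4, `O=C(Nc1ccc(C(F)(F)F)c(Cl)c1)c1cc(Br)ccc1O`, has not yet been measured. It differs from compound 3 by chloro in place of hydrogen on an aromatic carbon. This is the same kind of change as that from compound 1 to compound 2, though the surroundings are not the same: in compound 2 the chloro enters ortho to a large group and meta to a chloro group and to a fluoro group, whereas in compound 4 it enters ortho to a trifluoromethyl group and meta to a large group.

With no number for compound 3, there is no starting point from which the step to compound 4 can be applied, and only the values of compound 1 and compound 2 remain as a guide. Compound 4 is therefore expected to give a number in this assay in the region of those two, near 30 10^-6 cm/s, with a broad span from 10 10^-6 cm/s to 80 10^-6 cm/s.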

Compound 4, apparent permeability: 23.2 10^-6 cm/s
Beside the measured number, compound 4's estimate is 1.3-fold (0.11 log units) above it; low and high end bracket the measured number.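

Compound 3 has no number in this assay against which compound 4 at 23.2 10^-6 cm/s could be set, so the step between them cannot be read. Nothing at hand bears on this result. The compounds shown leave open whether chloro in place of hydrogen, ortho to a trifluoromethyl group, would repeat a 2.0-fold lower number from compound 1 to compound 2 (0.31 log units; beyond the scatter) or depart from it.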